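Moving the methyl on the pyridine amide of compound 2

The source may hold more compounds than are shown below. What is called first, only, known or untested is meant among the compounds shown, and "the series" means these compounds.

Compound 1 `Cc1cccc(F)c1N(C)C(=O)c1ccc(-c2ccc(O)cc2)o1` and compound 2 `Cc1ccncc1N(C)C(=O)c1ccc(-c2ccc(O)cc2)o1` share a core and differ only in the aryl group on the amide-type nitrogen. In an assay on cytosol from placenta for inhibition of 17-beta-hydroxysteroid dehydrogenase type 1 (Homo sapiens), read by HPLC, with a stated time of 10 min, in the presence of a further agent that is not named here (on this read-out higher numbers stand for weaker inhibition and lower numbers for stronger inhibition), compound 1 gives 310 nM, and compound 2 gives 260 nM. The step of a 1.2-fold lower number from compound 1 to compound 2 (0.08 log units; within the scatter) lies within the scatter, so these two numbers cannot be put in order. Compound 2 holds the lower of the two numbers, with compound 1 nearest and within the scatter of it.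

Compound 3 `Cc1ncccc1N(C)C(=O)c1ccc(-c2ccc(O)cc2)o1` has not yet been measured in this assay. It differs from compound 2 by 2-methylpyridin-3-yl in place of 4-methylpyridin-3-yl on an amide-type nitrogen; the two have the same atoms joined differently, with 2-methylpyridin-3-yl in place of 4-methylpyridin-3-yl on the amide-type nitrogen. Among the compounds with values here, the only measured step bearing on this position, a 1.2-fold lower number from compound 1 to compound 2 (0.08 log units; within the scatter), exchanged the whole aryl group and still stayed within the scatter. A rearrangement within the same pyridine is therefore expected to give no step beyond the scatter. The step of a 1.1-fold higher number from compound 2 to compound 3 (0.03 log units; within the scatter) is estimated to stay within the scatter. Compound 3 is expected to give 280 nM, in the range 120 nM to 650 nM.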

Compound 3, half-maximal inhibitory concentration: 160 nM
Compound 3: middle estimate off by 1.8-fold (0.24 log units), on the high side; measured number inside the range.
By their numbers in this assay, from the lowest: compounds 3, 2 and 1 (each within the scatter of the next).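

Moving the methyl group within the pyridine, with 2-methylpyridin-3-yl in place of 4-methylpyridin-3-yl on the amide-type nitrogen, gives a 1.6-fold lower number from compound 2 to compound 3 (0.21 log units; within the scatter) in this assay and so does not separate the two isomers on this read-out. Exchanging the whole aryl group gives a 1.9-fold lower number from compound 1 to compound 3 (0.29 log units; within the scatter) and also leaves the two compounds unresolved, so the three aryl groups tested on this nitrogen cannot be put in order, and none of the steps among them shows a clear effect of either the methyl placement or the change of aryl group. No evidence is available here that would explain these numbers.

The compounds shown leave open whether any aryl group on this nitrogen can move the number beyond the scatter, for example plain pyridin-3-yl without a methyl, or 2-methoxypyridin-3-yl with a methoxy group in place of the methyl. They also leave open what an ethyl group or a longer chain would do in place of the saturated chain carbon on the same nitrogen.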